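Ring Closure of the Acid Tail in Squalene Synthase Inhibitors

A few compounds are considered here, and "the series" means these few. Any claim that something is new, unique, unknown or untested is made for them only; others in the source may bear on it.

Compound 1, `CC(C)C[C@H]1C(=O)N(CC(=O)O)C[C@H](c2ccccc2Cl)c2cc(F)ccc21`: > 20000 nM
Compound 2, `CC(C)C[C@H]1C(=O)N(CC(=O)NCCCCCC(=O)O)C[C@H](c2ccccc2Cl)c2cc(Cl)ccc21`: 2400 nM

Of the compounds shown here, two have been tested in an assay on isolated protein for inhibition of squalene synthase (Homo sapiens), read by scintillation counting, with a stated time of 10 min; a higher number here means a weaker inhibitor, a lower number a stronger inhibitor. For compound 1 the result is only a limit of the assay, > 20000 nM (the limit of > 20000 nM in this assay, at which 1 of the 2 values shown sits). Within the data shown here, compound 2 gives 2400 nM in this assay, the single true number available, so it is the only anchor for any comparison. Compound 3, `CC(C)C[C@H]1C(=O)N(CC(=O)N2CCC(CC(=O)O)CC2)C[C@H](c2ccccc2Cl)c2cc(Cl)ccc21`, differs from compound 2 in one place: 4-(carboxymethyl)piperidin-1-yl in place of (5-carboxypentyl)amino on a carbonyl carbon. No change between two measured compounds is available to size this swap, and a closed acid tail of nearly the same length is expected to stay within the scatter, giving an estimated step of a 1.2-fold lower number from compound 2 to compound 3 (0.08 log units; within the scatter). Compound 3 is therefore expected to give about 2000 nM, between 700 nM and 6000 nM.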

Compound 3, half-maximal inhibitory concentration: 1400 nM
Beside the measured number, compound 3's estimate is 1.4-fold (0.15 log units) above it; low and high end bracket the measured number.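

In this assay the swap gives a 1.7-fold lower number from compound 2 to compound 3 (0.23 log units; within the scatter) and so the open-chain (5-carboxypentyl)amino tail and the 4-(carboxymethyl)piperidin-1-yl tail cannot be told apart. On this carbonyl carbon, then, an acid tail can carry a six-membered non-aromatic ring with no step beyond the scatter, something compound 1 and compound 2 alone could not show. Nothing measured here accounts for this result.

Still open, going by these compounds, is how the number would respond to a longer chain between the piperidine ring and the carboxylic acid, or to a primary amide in place of that acid.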